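The compounds below may be only part of what the source reports. "The series", "measured", "known", "first", "only" and "open" are said of these compounds alone.

Of the compounds shown here, three have so far been measured in an assay on CHO cells for displacement of a labelled ligand from Substance-P receptor (Homo sapiens), with a stated time of 90 min; on this read-out lower numbers stand for stronger inhibition and higher numbers for weaker inhibition. Compound 1 `O=C(NCc1cc(C(F)(F)F)cc(C(F)(F)F)c1)c1cnc2ccccc2c1-c1ccccc1` gives 208 nM in this assay. Compound 2 `CN(Cc1cc(C(F)(F)F)cc(C(F)(F)F)c1)C(=O)c1cnc2ccccc2c1-c1ccccc1` gives 92 nM in this assay. Going by the values given here, only one change separates these two, (methyl in place of hydrogen on an amide-type nitrogen), and that change made a step of a 2.3-fold lower number from compound 1 to compound 2 (0.35 log units; beyond the scatter).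

Compound 3 `Cc1nc(Cl)cc(-c2ccccc2)c1C(=O)NCc1cc(C(F)(F)F)cc(C(F)(F)F)c1` is built on a different core from compound 1; the difference between the two cores is not broken down here. In this assay compound 3 gives 270 nM. Against compound 1 this number lies within the scatter, so the two cannot be told apart on this read-out; against compound 2 the number of compound 3 is higher by more than the scatter.

Compound 4 `Cc1nc(Cl)cc(-c2ccccc2)c1C(=O)N(C)Cc1cc(C(F)(F)F)cc(C(F)(F)F)c1` has not yet been measured. Among the compounds with values here, it differs from compound 3 by methyl in place of hydrogen on an amide-type nitrogen, which is the same change as the one from compound 1 to compound 2: the group that leaves, the group that enters and the surroundings of the place are the same in both pairs. Among the compounds shown this change has been measured once, so any expectation rests on that single example and on the value of compound 3. Because the step of a 2.3-fold lower number from compound 1 to compound 2 (0.35 log units; beyond the scatter) was modest but beyond the scatter, a step of about the same size is expected when the same change is made on the core of compound 3, that is an expected step of a 2.3-fold lower number from compound 3 to compound 4 (0.35 log units; beyond the scatter). Compound 4 is therefore expected to give about 120 nM in this assay, with the estimate likely to fall between 60 nM and 240 nM.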

Compound 4, half-maximal inhibitory concentration: 91 nM
Beside the measured number, compound 4's estimate is 1.3-fold (0.12 log units) above it; low and high end bracket the measured number.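

In this assay, putting a methyl in place of the amide hydrogen on the core of compound 3 again gives a lower number, which here means stronger inhibition, with a 3.0-fold lower number from compound 3 to compound 4 (0.47 log units; beyond the scatter). Set beside the earlier example, the change carries over from one core to the other with a step of similar size, and the two steps cannot be told apart: the same change on two cores in this assay, a 2.3-fold lower number (0.35 log units; beyond the scatter) from compound 1 to compound 2 and a 3.0-fold lower number (0.47 log units; beyond the scatter) from compound 3 to compound 4, 1.3-fold (0.12 log units) apart, within the scatter of two such steps. Going by these compounds alone, this agreement rests on only two matched pairs, so it shows that the step transferred between these two cores, but it does not show that it would transfer to every core, and it gives no explanation of why the methyl lowers the number.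

The compounds shown carry only hydrogen or methyl on this amide-type nitrogen, so it remains open whether an ethyl group, a longer chain, or a chain ending in an amine or a carboxylic acid would lower the number further, leave it unchanged or raise it. As far as these compounds go, it also remains open whether the same change would give a similar step on a third core or on any read-out other than this assay.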